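Benzoyl on the amine nitrogen of compound 3

The source may report more compounds than this note shows. Statements on the series, on what has been measured and on what is new or still open speak of the compounds shown alone.

In a functional assay on MCF7 cells (Homo sapiens) for cytotoxicity, read by sulforhodamine B assay, with a stated time of 24 h (a lower number here means a stronger inhibitor, a higher number a weaker inhibitor), compound 3 (`N/N=C1\C(=O)Nc2ccc(S(=O)(=O)N3CCOCC3)cc21`) gives 46800 nM and stands level with the other two measured compounds. Compound 1 (`O=C1Nc2ccc(S(=O)(=O)N3CCOCC3)cc2/C1=N/c1cccc(C(F)(F)F)c1`) gives 41100 nM and compound 2 (`Cc1ccc(S(=O)(=O)N/N=C2\C(=O)Nc3ccc(S(=O)(=O)N4CCOCC4)cc32)cc1`) gives 38400 nM in the same read-out, so all three numbers lie within the scatter of one another.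

Compound 4 (`O=C1Nc2ccc(S(=O)(=O)N3CCOCC3)cc2/C1=N/NC(=O)c1ccccc1`) carries benzoyl in place of hydrogen on an amine nitrogen, which turns amino into benzamido.

Among the measured compounds shown here, two measured steps bear on this change. Amino in place of 3-(trifluoromethyl)phenyl on a double-bonded nitrogen gave a 1.1-fold higher number from compound 1 to compound 3 (0.06 log units; within the scatter) and hydrogen in place of (4-methylphenyl)sulfonyl on an amine nitrogen gave a 1.2-fold higher number from compound 2 to compound 3 (0.09 log units; within the scatter) on the same nitrogen that takes the benzoyl. Neither step goes beyond the scatter.

No step beyond the scatter is therefore expected in this assay in either direction, and the expected change is a 1.1-fold lower number from compound 3 to compound 4 (0.05 log units; within the scatter) at most a nominal one. For compound 4 the estimated value is 42000 nM with an expected range of 22000 nM to 80000 nM around it.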

Compound 4, half-maximal inhibitory concentration: 414000 nM
Estimate against measurement, compound 4: 9.9-fold (0.99 log units) below, outside the stated range (above it).
By their numbers in this assay, from the lowest: compounds 2, 1 and 3 (each within the scatter of the next); then compound 4.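

Among the compounds shown here, on this amine nitrogen, the earlier compounds gave no sign that the substituent matters, but in this assay benzoyl in place of hydrogen gives an 8.8-fold higher number from compound 3 to compound 4 (0.95 log units; beyond the scatter), so this position does respond to at least one group. Benzoyl in place of (4-methylphenyl)sulfonyl gives an 11-fold higher number from compound 2 to compound 4 (1.03 log units; beyond the scatter), and benzamido in place of 3-(trifluoromethyl)phenyl on the double-bonded nitrogen gives a 10-fold higher number from compound 1 to compound 4 (1.00 log units; beyond the scatter), so an aromatic ring at this end of the molecule is not enough on its own to produce the shift, since compounds 1 and 2 also carry one. No measurement available here accounts for the effect of benzoyl.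

Going by these compounds, what an acetyl group, with a carbonyl but no ring, or a benzyl group, with a ring but no carbonyl, would do on this nitrogen remains open. Also open, on these data alone, is whether a methoxy or chloro substituent on the benzoyl ring would move the number back towards that of compound 3.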